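The source may report more compounds than this note shows. Statements on the series, on what has been measured and on what is new or still open speak of the compounds shown alone.

In an assay for inhibition of leukotriene B4 receptor 1 (Homo sapiens) (a higher number here means a weaker inhibitor, a lower number a stronger inhibitor), compound 2 `CCCCCCCCC(O)/C=C/c1cccc(CC(O)c2cccc(C(=O)O)c2)n1` gives 1 nM, the lower of the two numbers in hand. Compound 1 `CCCCCCCCC(O)c1ccc2ccc(/C=C/CCCC(=O)O)nc2c1` gives 1400 nM in this assay, a gap far beyond the scatter; the two compounds differ at several places at once, so nothing beyond their two values is drawn from the pair. Compound 3 `CCCCOc1cccc(C(O)/C=C/c2cccc(CC(O)c3cccc(C(=O)O)c3)n2)c1` differs from compound 2 in one place: 3-butoxyphenyl in place of octyl on a saturated chain carbon bound to a double-bonded chain carbon and an oxygen on a saturated carbon. Going by the values given here, no single-point step is available to set the size of this change. For compound 3 a step of a 3.0-fold higher number from compound 2 to compound 3 (0.48 log units; beyond the scatter) is expected, in the direction of a somewhat higher number, likely within or just beyond the scatter. Compound 3 is estimated at 3 nM, with a range of 0.5 nM to 20 nM.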

Compound 3, inhibition constant: 3 nM
Beside the measured number, compound 3's estimate shows no gap at the digits printed; low and high end bracket the measured number.
By their numbers in this assay, from the lowest: compound 2; then compound 3; then compound 1.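

In this assay the saturated chain carbon bound to a double-bonded chain carbon and an oxygen on a saturated carbon carries an aromatic ring as well as a plain chain. Replacing octyl with 3-butoxyphenyl gives a 3.0-fold higher number from compound 2 to compound 3 (0.48 log units; beyond the scatter) and so costs only a modest step. The octyl chain is therefore not essential at this position for a strong inhibitor. As far as these compounds go, what the butoxy chain adds to the ring stays open, and an unsubstituted phenyl or a 3-methoxyphenyl here would separate the two. No measurement on hand explains the step.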